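Ester in place of acid on the benzyl ring

The compounds below may be only part of what the source reports. "The series", "measured", "known", "first", "only" and "open" are said of these compounds alone.

Measured so far in a functional assay on SK-OV-3 cells (Homo sapiens) for inhibition, read by CCK-8 assay, with a stated time of 70 h; on this read-out lower numbers stand for stronger inhibition and higher numbers for weaker inhibition:
compound 1 `c1ccc(COc2ccc(OCCOCCOC3CCCC3)cc2)cc1`: > 100000 nM
compound 2 `O=C(O)c1ccccc1COc1ccc(OCCOCCNC2CCCC2)cc1`: > 100000 nM
compound 3 `c1ccc(COc2ccc(OCCOCCNC3CC3)cc2)cc1`: 47200 nM

Compound 2 gives only a limit in this assay, > 100000 nM, not a number. It shares that position with one other compound, as the limit of > 100000 nM in this assay, at which 2 of the 3 values shown sit, shows. Compound 3 is the only one of the three with a numerical value in this assay, 47200 nM. For the measured compounds named here, the single step between measured compounds that differ in one place, an at least 2.1-fold lower number from compound 1 to compound 3 (0.32 log units; beyond the scatter), concerns the chain end and not the aromatic ring, so it does not bear on the change under study.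

Compound 4 `COC(=O)c1cccc(COc2ccc(OCCOCCNC3CCCC3)cc2)c1` is still to be measured. It differs from compound 2 by 3-(methoxycarbonyl)phenyl in place of 2-carboxyphenyl on a saturated chain carbon bound to an oxygen on an aromatic ring. Going by the values given here, no measured step covers this change, and compound 2 offers only a limit to start from, so the size of the step is not predictable from the data. The estimate for compound 4 is therefore a weak value of 60000 nM, between 20000 nM and 150000 nM, which means an expected step of an at least 1.6-fold lower number from compound 2 to compound 4 (0.22 log units; that floor lies within the scatter) with a fair chance that only a limit is reported.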

Compound 4, half-maximal inhibitory concentration: 45500 nM
Compound 4: the middle estimate sits 1.3-fold (0.12 log units) above what was measured, and the stated range covers the measured number.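

In this assay, for the compounds shown here, 3-(methoxycarbonyl)phenyl in place of 2-carboxyphenyl on a saturated chain carbon bound to an oxygen on an aromatic ring gives an at least 2.1-fold lower number from compound 2 to compound 4 (0.34 log units; beyond the scatter), the first measured step at this place and the first sign that the benzyl ring substituent can shift the read-out. Compound 2 remains a limit, so this step has only a floor and its full size stays unknown: the limit of > 100000 nM in this assay, at which 2 of the 4 values shown sit.

The change alters the ring place of the group and replaces the acid with an ester together, so the step cannot assign the difference to either one.

A carboxylic acid at the ring place of the ester in compound 4 would separate these two changes. On these data alone, whether a primary amide at that place reads like the ester also remains open.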